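Hydroxy to methoxy in three inactive benzamides

The source may hold more compounds than are shown below. What is called first, only, known or untested is meant among the compounds shown, and "the series" means these compounds.

Compound 2, `O=C(Nc1ccccc1)c1cc(Br)cc(Br)c1O`, carries a free hydroxy on its aromatic ring. In an assay on isolated protein for inhibition of thiosulfate sulfurtransferase (Homo sapiens), with a stated time of 60 min, in the absence of a further agent (on this read-out lower numbers stand for stronger inhibition and higher numbers for weaker inhibition), compound 2 gives > 100000 nM, which is a limit of the assay and not a number. Compound 1, `COc1c(Br)cc(Br)cc1C(=O)Nc1ccccc1`, is its methyl ether. In this assay compound 1 gives > 100000 nM, again a limit rather than a number. The change between them is methyl in place of hydrogen on an oxygen on an aromatic ring and the step is a step that the two limits leave unreadable from compound 2 to compound 1.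

Compound 3, `O=C(Nc1ccc(Sc2nc3ccccc3s2)cc1)c1cc(Br)cc(Br)c1O`, carries a larger substituent on the anilide side; the difference between its core and that of compound 2 is not broken down here. In this assay compound 3 gives > 100000 nM, once more a limit and not a number.

Compound 4, `COc1c(Br)cc(Br)cc1C(=O)Nc1ccc(Sc2nc3ccccc3s2)cc1`, has not been measured. It differs from compound 3 by methyl in place of hydrogen on an oxygen on an aromatic ring, the same change that separates compound 2 from compound 1. What is known rests on (the limit of > 100000 nM in this assay, at which 3 of the 3 values shown sit).

He expects the step that the limit leaves unreadable from compound 3 to compound 4 for compound 4 to be unreadable in the same way, because the limit of > 100000 nM in this assay, at which 3 of the 3 values shown sit, and because a step that the two limits leave unreadable from compound 2 to compound 1 left the earlier instance of the same change without a readable size. For compound 4 he therefore estimates 150000 nM, with a range from 50000 nM to 500000 nM, and expects the assay to return only a limit.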

Compound 4, half-maximal inhibitory concentration: > 100000 nM
Compound 4: only a limit was reported (the forecaster's own chance of this, stated with the estimate: 85%); the middle value does not contradict the limit.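

In this assay compound 4 gives > 100000 nM, a limit and not a number, and no size can be read for the change from hydroxy to methoxy between compound 3 and compound 4. The compounds shown leave open what size this change has, or whether it has any effect at all on inhibition, as none of them yields a number in this assay: the limit of > 100000 nM in this assay, at which 4 of the 4 values shown sit.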